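The source may report more compounds than this note shows. Statements on the series, on what has been measured and on what is new or still open speak of the compounds shown alone.

Working notes on the series. For the measured compounds named here, compound 2 `COCCn1nc(C(=O)N[C@H]2COc3ccccc3N(C)C2=S)nc1Cc1ccccc1` stands at the high end of the three numbers so far: in a functional assay on HT-29 cells (Homo sapiens) for inhibition, read by luminescence and CellTiter-Glo, with a stated time of 24 h (a lower number here means that less compound is needed, a higher number that more compound is needed for the effect), compound 2 gives 566 nM, with compound 3 `CN1C(=S)[C@@H](NC(=O)c2nc(Cc3ccccc3)n(C3CCC3)n2)COc2ccccc21` at 181 nM nearest to it and compound 1 `CN1C(=S)[C@@H](NC(=O)c2nc(Cc3ccccc3)n(C)n2)COc2ccccc21` at 2.5 nM furthest away. The next compound to be measured is compound 4 `CN1C(=S)[C@@H](NC(=O)c2nc(Cc3ccccc3)n(CC3COC3)n2)COc2ccccc21`. How it differs from compound 2: oxetan-3-yl in place of methoxymethyl on a saturated chain carbon bound to an aromatic nitrogen.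

Going by the values given here, three measured steps bear on this. The ring-bearing substituent in compound 4 is larger than methyl, and both prior departures from methyl on the aromatic nitrogen cost potency, with a 230-fold higher number from compound 1 to compound 2 (2.35 log units; beyond the scatter) and a 72-fold higher number from compound 1 to compound 3 (1.86 log units; beyond the scatter). Between the two larger substituents the contrast was smaller, a 3.1-fold lower number from compound 2 to compound 3 (0.50 log units; beyond the scatter), so a move from compound 2 to another larger group is expected to fall in that modest range, most likely toward a lower number. The expected step in this assay is a 2.3-fold lower number from compound 2 to compound 4 (0.35 log units; beyond the scatter). Compound 4 is thus estimated at 250 nM, with a range from 60 nM to 1000 nM.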

Compound 4, half-maximal effective concentration: 2830 nM
For compound 4 the middle estimate is 11-fold (1.05 log units) below the measured one; measured number above the stated range.
By their numbers in this assay, from the lowest: compound 1; then compound 3; then compound 2; then compound 4.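

Closing the methoxymethyl end of the chain into oxetan-3-yl, on a saturated chain carbon bound to an aromatic nitrogen, brings no return toward the low numbers in this assay and instead gives a 5.0-fold higher number from compound 2 to compound 4 (0.70 log units; beyond the scatter). With a 1100-fold higher number from compound 1 to compound 4 (3.05 log units; beyond the scatter), the cost of replacing methyl on the aromatic nitrogen proves not to be a single level but to depend strongly on the group that enters. The two oxygen-bearing groups both stand above cyclobutyl, and a 16-fold higher number from compound 3 to compound 4 (1.19 log units; beyond the scatter) shows that this position separates the larger groups from one another as well as from methyl.

No measurement shown accounts for these steps. Open, on these data alone, is how ethyl, with a smaller carbon-only chain, or a chain ending in a dimethylamino group would stand against methyl and cyclobutyl at this position.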